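Carbamate in place of thiocarbamate on the sugar-side oxygen

A few compounds are considered here, and "the series" means these few. Any claim that something is new, unique, unknown or untested is made for them only; others in the source may bear on it.

Measured compounds and their numbers in an assay on DDT1 cells (Cricetulus griseus) for binding affinity to adenosine receptor A1 (Homo sapiens), read by radioligand binding; on this read-out higher numbers stand for weaker inhibition and lower numbers for stronger inhibition:
compound 1, `CNC(=O)OC[C@H]1OC(n2cnc3c(NC4CCOC4)nc(Cl)nc32)[C@H](O)[C@@H]1O`: 96 nM
compound 2, `C/N=C(\S)OC[C@H]1OC(n2cnc3c(NC4CCOC4)ncnc32)[C@H](O)[C@@H]1O`: 45 nM
compound 3, `CCC/N=C(\S)OC[C@H]1OC(n2cnc3c(NC4CCOC4)ncnc32)[C@H](O)[C@@H]1O`: 50 nM

Compound 3 stands second highest of the three numbers. Its nearest neighbour is compound 2, and the step of a 1.1-fold higher number from compound 2 to compound 3 (0.05 log units; within the scatter) lies within the scatter. Among the compounds with values here, compound 1 gives the highest number of the three, yet its value and that of compound 3 are also within the scatter of each other; compound 1 further carries a chlorine on the shared core, so no single step connects it to compound 3.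

Compound 4, `CC(C)NC(=O)OC[C@H]1OC(n2cnc3c(NC4CCOC4)ncnc32)[C@H](O)[C@@H]1O`, differs from compound 3 by a group of 6 heavy atoms (4 carbon, 1 nitrogen, 1 oxygen; no ring) in place of a group of 6 heavy atoms (4 carbon, 1 nitrogen, 1 sulfur; no ring), on an oxygen on a saturated carbon. Within the data shown here, the only measured single step, a 1.1-fold higher number from compound 2 to compound 3 (0.05 log units; within the scatter), changes the chain on the nitrogen of the same group and is within the scatter; it does not speak to the exchange of sulfur for oxygen. Compound 1 shows a carbamate of the same kind with a number within the scatter of compound 3, though with a second change present. On these grounds no step beyond the scatter is expected for compound 4 in this assay; the estimate is 70 nM, with a range from 25 nM to 200 nM, which corresponds to a 1.4-fold higher number from compound 3 to compound 4 (0.15 log units; within the scatter).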

Compound 4, inhibition constant: 78 nM
Beside the measured number, compound 4's estimate is 1.1-fold (0.05 log units) below it, within the range that was stated.
By their numbers in this assay, from the lowest: compounds 2, 3, 4 and 1 (each within the scatter of the next, the first and the last beyond it).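

In this assay isopropylcarbamoyl puts oxygen where the groups of compound 2 and compound 3 hold sulfur on the same core without chlorine, and the exchange reads as a 1.6-fold higher number from compound 3 to compound 4 (0.19 log units; within the scatter) on this oxygen on a saturated carbon. Measured against the shorter group, the change reads as a 1.7-fold higher number from compound 2 to compound 4 (0.24 log units; within the scatter), so neither step separates the new group from the sulfur-bearing groups, and on this core the position tolerates oxygen in that group as well as sulfur in this assay. Nothing measured here offers a reason for how closely these numbers sit.

The step from compound 3 to compound 4 changes the sulfur and the chain on the nitrogen together, so the exchange of sulfur for oxygen with the chain held constant remains unresolved. From the compounds shown here alone, it is also open how this assay would read with a much larger or differently built group at this position, such as a benzyl group on the carbamate nitrogen, a longer chain such as octyl, or a carboxylic acid in place of isopropylcarbamoyl.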